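Cyclopropyl hydroxamic acid replaces methyl amide on shared scaffold

The compounds below may be only part of what the source reports. "The series", "measured", "known", "first", "only" and "open" are said of these compounds alone.

Measured compounds: compound 1 `O=C(O)COc1ccc(NCc2cccc(Oc3ccccc3)c2)cc1` gives 2040 nM in a functional assay on CHO cells for agonist activity at Free fatty acid receptor 1 (Homo sapiens); on this read-out higher numbers stand for an effect only at larger amounts of compound and lower numbers for an effect already at smaller amounts; compound 2 `CC(Cc1ccc(NCc2cccc(Oc3ccccc3)c2)cc1)C(=O)O` gives 100 nM; compound 3 `CNC(=O)CCc1ccc(NCc2cccc(Oc3ccccc3)c2)cc1` gives 49 nM.

Compound 3 holds the lowest number of the three: compound 2 sits at a 2.0-fold lower number from compound 2 to compound 3 (0.31 log units; beyond the scatter) and compound 1 at a 42-fold lower number from compound 1 to compound 3 (1.62 log units; beyond the scatter). Compound 4 `O=C(NO)[C@H]1C[C@@H]1c1ccc(NCc2cccc(Oc3ccccc3)c2)cc1` changes the same side of the shared core: 2-(hydroxycarbamoyl)cyclopropyl in place of 2-(methylcarbamoyl)ethyl on an aromatic carbon. The two steps ending at compound 3 show that this position tolerates large swings, with a 42-fold lower number from compound 1 to compound 3 (1.62 log units; beyond the scatter) and a 2.0-fold lower number from compound 2 to compound 3 (0.31 log units; beyond the scatter) both heading toward lower numbers. For the measured compounds named here, no measured step covers a ring or a hydroxycarbamoyl group, so the direction is uncertain; a modest move to a higher number is expected, a 3.1-fold higher number from compound 3 to compound 4 (0.49 log units; beyond the scatter). Compound 4 is estimated at 150 nM, within 40 nM to 600 nM.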

Compound 4, half-maximal effective concentration: 14.8 nM
Compound 4: the middle estimate sits 10-fold (1.01 log units) above what was measured, and the stated range ends above it.
By their numbers in this assay, from the lowest: compound 4; then compound 3; then compound 2; then compound 1.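

For the compounds shown here, the position accepts a 2-(hydroxycarbamoyl)cyclopropyl group, the only one here with a ring, and the numbers keep falling, with a 3.3-fold lower number from compound 3 to compound 4 (0.52 log units; beyond the scatter) and a 6.8-fold lower number from compound 2 to compound 4 (0.83 log units; beyond the scatter) and a 140-fold lower number from compound 1 to compound 4 (2.14 log units; beyond the scatter) on the same side of the shared core. This change brings in the ring and the hydroxycarbamoyl group together, and the compounds shown cannot separate the two. No measurement at hand explains the shift. Going by these compounds, it remains open how a cyclopropyl ring carrying a carboxylic acid or a methylcarbamoyl group would read, and how a 2-(hydroxycarbamoyl)ethyl chain without the ring would compare.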